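Swapping bromo for cyano on compound 2

The source may report more compounds than this note shows. Statements on the series, on what has been measured and on what is new or still open speak of the compounds shown alone.

Among the measured compounds shown here, in an ADME assay on H9 cells (Homo sapiens) for cytotoxicity, read by XTT assay, with a stated time of 6 days (on this read-out higher numbers stand for lower toxicity in this test and lower numbers for higher toxicity in this test), compound 2 `Cc1cc(Br)cc(C)c1Oc1ccc(N)c(Nc2ccc(C#N)cc2)c1` gives 44600 nM, the only exact number so far. Compound 1 `Cc1cc(C#N)cc(C)c1Oc1ccc([N+](=O)[O-])c(Nc2ccc(C#N)cc2)c1` gives only a limit, > 65100 nM. Compound 3 `Cc1cc(C#N)cc(C)c1Oc1ccc(N)c(Nc2ccc(C#N)cc2)c1` has cyano in place of bromo on an aromatic carbon of compound 2 (cyano in place of bromo on an aromatic carbon). For the measured compounds named here, no measured pair of compounds tests this swap, so the estimated 1.1-fold higher number from compound 2 to compound 3 (0.05 log units; within the scatter) in this assay is expected to stay within the usual scatter, with no firm direction. Compound 3 is expected to read 50000 nM, with an estimated range of 20000 nM to 110000 nM.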

Compound 3, half-maximal cytotoxic concentration: 49800 nM
Compound 3: the middle estimate sits 1.0-fold (0.00 log units) above what was measured; the measured number falls inside the stated range.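

In this assay, among the compounds shown here, cyano in place of bromo on this aromatic carbon gives a 1.1-fold higher number from compound 2 to compound 3 (0.05 log units; within the scatter), so this is the first direct sign that the two groups cannot be told apart here. Amino in place of nitro, at a different place on the core, gives an at least 1.3-fold lower number from compound 1 to compound 3 (0.11 log units; that floor lies within the scatter). Compound 1 has a limit rather than a number, so that step has only a floor: the limit of > 65100 nM in this assay, at which 1 of the 3 values shown sits.

As far as these compounds go, whether a carboxylic acid or a methoxy group on this carbon would move the number stays open. From the compounds shown here alone, the true distance between compound 1 and compound 3 also stays open.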